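Shortening a Basic Side Chain on a Shared Core

The source may hold more compounds than are shown below. What is called first, only, known or untested is meant among the compounds shown, and "the series" means these compounds.

Of the compounds shown here, two with a shared core have been measured in a functional assay on SH-SY5Y cells (Homo sapiens) for cytotoxicity, read by MTT assay, with a stated time of 72 h; a lower number here means a stronger inhibitor, a higher number a weaker inhibitor. Compound 1, `CN1CCN(CCCCCCn2c3c(c4ccccc42)C(=O)c2c[n+]([O-])c4ccccc4c2C3=O)CC1`, gives 920 nM in this assay. Compound 2, `O=C1c2c[n+]([O-])c3ccccc3c2C(=O)c2c1c1ccccc1n2Cc1cn([C@H]2O[C@H](CO)[C@@H](O)[C@H]2O)nn1`, gives 1340 nM in this assay. Compound 1 has the lowest of the two numbers, yet its gap to compound 2 lies within the scatter, so the two cannot be told apart on these numbers. Compound 3, `O=C1c2c[n+]([O-])c3ccccc3c2C(=O)c2c1c1ccccc1n2CCN1CCCC1`, has not been measured. It differs from compound 1 in one place: pyrrolidin-1-yl in place of 4-(4-methylpiperazin-1-yl)butyl on a saturated chain carbon, two bonds along the chain from an aromatic nitrogen. Within the data shown here, no step between measured compounds covers a change of this kind, so there is no measured guide to its size. With only the scatter-sized spread between compound 1 and compound 2 to go on, the expected step is a 1.1-fold higher number from compound 1 to compound 3 (0.04 log units; within the scatter), that is, nothing beyond the scatter. Compound 3 is therefore expected to give about 1000 nM in this assay, within a range from 300 nM to 3500 nM.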

Compound 3, half-maximal inhibitory concentration: 520 nM
Compound 3: the middle estimate sits 1.9-fold (0.28 log units) above what was measured; measured number inside the range.
By their numbers in this assay, from the lowest: compounds 3, 1 and 2 (each within the scatter of the next, the first and the last beyond it).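

In this assay, among these compounds, the swap of 4-(4-methylpiperazin-1-yl)butyl for pyrrolidin-1-yl, on a saturated chain carbon two bonds along the chain from an aromatic nitrogen, gives a 1.8-fold lower number from compound 1 to compound 3 (0.25 log units; within the scatter) and so no step that can be told from repeat-measurement noise. This position therefore accepts a far smaller group, with one ring nitrogen in place of two and a much shorter reach, without a clear loss or gain in this cytotoxicity read-out. No measurement at hand offers an explanation for this result.

As far as these compounds go, what a chain ending in a carboxylic acid or a plain methyl group would give here stays open, so it is unknown whether an amine at the chain end matters at all. Chain length and ring type also change together in this step, and a longer chain ending in pyrrolidin-1-yl would be needed to separate them.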